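Chain length and cytotoxicity across four related compounds

The source may report more compounds than this note shows. Statements on the series, on what has been measured and on what is new or still open speak of the compounds shown alone.

Compound 1, `CCCCCOc1nc(N)nc2c1ncn2/C=C1/CC1(CO)CO`: > 20000 nM, a limit of the assay.
Compound 2, `CCCOc1nc(N)nc2c1ncn2/C=C1/CC1(CO)CO`: > 20000 nM, a limit of the assay.
Compound 3, `CCCCCCOc1nc(N)nc2c1ncn2/C=C1/CC1(CO)CO`: > 20000 nM, a limit of the assay.

The three measured compounds share one core and differ only in the chain that starts at the oxygen on the aromatic ring. In an ADME assay on BCBL1 cells (Homo sapiens) for cytotoxicity, with a stated time of 7 days (on this read-out higher numbers stand for lower toxicity in this test and lower numbers for higher toxicity in this test), compound 1 reaches only a limit, > 20000 nM. Compound 2 likewise stops at the limit, > 20000 nM. Compound 3 too is reported only as the limit, > 20000 nM. Compound 2 differs from compound 1 by hydrogen in place of ethyl on a saturated chain carbon, three bonds along the chain from an oxygen on an aromatic ring, and that step is a step that the two limits leave unreadable from compound 1 to compound 2. Compound 3 differs from compound 1 by methyl in place of hydrogen on a saturated chain carbon, five bonds along the chain from an oxygen on an aromatic ring, and that step is a step that the two limits leave unreadable from compound 1 to compound 3; the step from compound 2 to compound 3 is a step that the two limits leave unreadable from compound 2 to compound 3. All three sit at the limit of > 20000 nM in this assay, at which 3 of the 3 values shown sit, so none of these steps can be read.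

Compound 4, `CCCCOc1nc(N)nc2c1ncn2/C=C1/CC1(CO)CO`, has not yet been measured in this assay. It differs from compound 3 by hydrogen in place of ethyl on a saturated chain carbon, four bonds along the chain from an oxygen on an aromatic ring. Going by the values given here, this is the same kind of change as the one from compound 1 to compound 2, but the place differs: there the hydrogen enters three bonds along the chain from an oxygen on an aromatic ring, here four bonds along the chain from an oxygen on an aromatic ring. For compound 4 the step that the limit leaves unreadable from compound 3 to compound 4 is expected to remain just as unreadable as its counterpart, because the three measured compounds all sit at the limit of > 20000 nM in this assay, at which 3 of the 3 values shown sit. Compound 4 is therefore estimated at 25000 nM, between 20000 nM and 40000 nM, and most probably it will again be reported only as a limit.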

Compound 4, half-maximal cytotoxic concentration: > 20000 nM
Compound 4: a limit, no number (the forecaster's own chance of this, stated with the estimate: 85%); the middle value is on the limit's open side.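

In this assay compound 4 gives > 20000 nM, which is a limit of the assay and not a number. The steps linking compound 4 with compound 1, compound 2 and compound 3 therefore cannot be read: the limit of > 20000 nM in this assay, at which 4 of the 4 values shown sit.

The compounds shown leave open whether changing the chain has any effect on cytotoxicity in this assay, and at what concentration any of the four would reach the half-maximal effect.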